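The source may report more compounds than this note shows. Statements on the series, on what has been measured and on what is new or still open speak of the compounds shown alone.

Compound 2 `COc1ccc(Cl)cc1S(=O)(=O)Nc1cncc(-c2ccccc2C)c1` and compound 1 `COc1ccc(Cl)cc1S(=O)(=O)Nc1cncc(-c2cccnc2)c1` share one core and differ only in the aromatic group attached to it. In an assay on isolated protein for inhibition of alkaline phosphatase, tissue-nonspecific isozyme (Homo sapiens) (a higher number here means a weaker inhibitor, a lower number a stronger inhibitor), compound 1 gives 73 nM. In this assay, for the measured compounds named here, compound 2 gives 178 nM, the higher of the two numbers measured so far; the step of a 2.4-fold higher number from compound 1 to compound 2 (0.39 log units; beyond the scatter) shows how far it sits from compound 1. Compound 3 `CCNC(=O)c1cncc(NS(=O)(=O)c2cc(Cl)ccc2OC)c1` arises from compound 2 by the change (ethylcarbamoyl in place of 2-methylphenyl on an aromatic carbon). Going by the values given here, no measured step covers this kind of exchange, in which a ring leaves and an open chain with a donor and an acceptor enters; the only step in hand, a 2.4-fold higher number from compound 1 to compound 2 (0.39 log units; beyond the scatter), concerns swapping one ring for another. The expected step from compound 2 to compound 3 in this assay is therefore a 1.4-fold higher number from compound 2 to compound 3 (0.15 log units; within the scatter), with wide uncertainty. Compound 3 is estimated at 250 nM, within a range from 60 nM to 1000 nM.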

Compound 3, half-maximal inhibitory concentration: 193 nM
Estimate against measurement, compound 3: 1.3-fold (0.11 log units) above; measured number inside the range.
By their numbers in this assay, from the lowest: compound 1; then compounds 2 and 3 (each within the scatter of the next).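

At this position on the shared core, a ring is not required: in this assay the step of a 1.1-fold higher number from compound 2 to compound 3 (0.04 log units; within the scatter) puts the open-chain ethylcarbamoyl level with the 2-methylphenyl ring, even though the two groups share no ring and differ in hydrogen-bond donors and acceptors. The pyridin-3-yl group still gives the strongest inhibitor of the three, since the step of a 2.6-fold higher number from compound 1 to compound 3 (0.42 log units; beyond the scatter) is beyond the scatter, as is the step from compound 1 to compound 2. No measurement here explains why these different groups give such results.

From the compounds shown here alone, it remains open whether the amide hydrogen of ethylcarbamoyl matters, which a dimethylcarbamoyl group could test. A longer chain such as propylcarbamoyl, or a carboxylic acid at this position, could show how much further this position tolerates change.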